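Swapping Trifluoromethyl for Methoxy on the Aryl Ring

The source may report more compounds than this note shows. Statements on the series, on what has been measured and on what is new or still open speak of the compounds shown alone.

Going by the values given here, in a functional assay on HL-60 cells (Homo sapiens) for cytotoxicity, read by MTT assay, with a stated time of 4 days (on this read-out higher numbers stand for weaker inhibition and lower numbers for stronger inhibition), compound 2 `C=C1C(=O)[C@]23C[C@@]1(O)CC[C@H]2c1ccc(O)c(C)c1[C@@H]3Cn1cc(-c2ccc(C(F)(F)F)cc2)nn1` gives 720 nM, the only numerical value among the three measured compounds. Compound 1 `C=C1C[C@]23C[C@@]1(O)CC[C@H]2c1ccc(O)c(C)c1[C@@H]3Cn1cc(-c2ccc(Br)cc2)nn1` reaches only the limit of the assay, > 20000 nM. Compound 3 `C=C1C[C@]23C[C@@]1(O)CC[C@H]2c1cc(Br)c(O)c(C)c1[C@@H]3Cn1cc(-c2ccccc2)nn1` likewise reaches only the limit, > 20000 nM. What remains as evidence is the limit of > 20000 nM in this assay, at which 2 of the 3 values shown sit, so compound 2 alone gives a number to build on. Compound 4 `C=C1C(=O)[C@]23C[C@@]1(O)CC[C@H]2c1ccc(O)c(C)c1[C@@H]3Cn1cc(-c2ccc(OC)cc2)nn1` is not yet measured; it differs from compound 2 by methoxy in place of trifluoromethyl on an aromatic carbon. Among the compounds with values here, no measured pair shows this exchange, so no direction can be read off. The expected step of a 2.1-fold higher number from compound 2 to compound 4 (0.32 log units; beyond the scatter) is modest, within or just beyond the usual scatter. Compound 4 is estimated at 1500 nM, with a range from 400 nM to 6000 nM.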

Compound 4, half-maximal inhibitory concentration: 1150 nM
The estimate for compound 4 lay 1.3-fold (0.12 log units) above the measured number; the range from low to high includes it.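

In this assay, methoxy in place of trifluoromethyl on an aromatic carbon, para to a large group, gives a 1.6-fold higher number from compound 2 to compound 4 (0.20 log units; within the scatter). At this position, then, the two groups give values that cannot be told apart, although methoxy carries a hydrogen-bond acceptor and trifluoromethyl none. This is the first readable exchange here, and the other compounds add none: the limit of > 20000 nM in this assay, at which 2 of the 4 values shown sit.

From the compounds shown here alone, whether an amine or a carboxylic acid at this same position would also keep a measurable value stays open. So does the part played by the carbonyl that compound 2 and compound 4 share, as no pair shown differs there alone.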